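Swapping the Ring on the Amide of Compound 2

The source may report more compounds than this note shows. Statements on the series, on what has been measured and on what is new or still open speak of the compounds shown alone.

Of the compounds shown here, two with a shared core have been measured so far, compound 1 `CC(=O)NCc1cccc(Cn2nc(NS(=O)(=O)c3ccc(Cl)s3)c3c(F)cccc32)c1` and compound 2 `COc1cccc2c1c(NS(=O)(=O)c1ccc(Cl)s1)nn2Cc1cccc(CNC(=O)C2CCO2)c1`. Compound 1 reads >= 139 ug/mL in a physicochemical assay for solubility, read by chemiluminescence, measured as kinetic solubility (a lower number here means a less soluble compound, a higher number a more soluble compound), which is a limit of the assay and not a number. Within the data shown here, compound 2 gives 124 ug/mL, the only exact value available so far.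

Compound 3 `COc1cccc2c1c(NS(=O)(=O)c1ccc(Cl)s1)nn2Cc1cccc(CNC(=O)[C@@H]2CCCCN2)c1` keeps the core of compound 2 but carries piperidin-2-yl in place of oxetan-2-yl on a carbonyl carbon. Among the measured compounds shown here, no measured pair shows a change of this kind, so the expectation starts from compound 2 at 124 ug/mL. No step beyond the usual scatter is expected in this assay, in either direction. The expected change, a 1.1-fold lower number from compound 2 to compound 3 (0.03 log units; within the scatter), is small. Compound 3 is expected at about 115 ug/mL, with an estimated range of 60 ug/mL to 165 ug/mL.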

Compound 3, solubility: >= 220 ug/mL
Compound 3: no number, only a limit; the forecaster's own chance of this, stated with the estimate: 35%; at least 1.9-fold (0.28 log units) between middle value and limit.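

Piperidin-2-yl in place of oxetan-2-yl on a carbonyl carbon gives the first step read at this position: an at least 1.7-fold higher number from compound 2 to compound 3 (0.24 log units; that floor lies within the scatter). In this assay, going by these compounds, compound 3 gives >= 220 ug/mL, which is a limit of the assay and not a number, so the full size of the step stays unknown. This position can therefore take the six-membered ring, with its nitrogen and its hydrogen-bond donor, without a lower number, although the floor of the step alone does not clear the usual scatter.

This single pair cannot separate the effect of ring size from that of the ring nitrogen. It also leaves open how an open-chain amine, a carboxylic acid or the mirror-image form of piperidin-2-yl would read on the same carbonyl carbon.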